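The compounds below may be only part of what the source reports. "The series", "measured", "known", "first", "only" and "open" are said of these compounds alone.

In a functional assay on MCF7 cells (Homo sapiens) for inhibition, read by resazurin assay, with a stated time of 24 h (a lower number here means a stronger inhibitor, a higher number a weaker inhibitor), compound 1 `O=C1Nc2c(C(F)(F)F)cccc2[C@@]1(c1ccc(O)cc1)C1CCC(F)(F)CC1` gives > 1000 nM, which is a limit of the assay and not a number. Going by the values given here, the only other compound measured so far, compound 2 `O=C1Nc2c(C(F)(F)F)cccc2C1(c1ccc(OC(F)(F)F)cc1)c1ccc(O)c(F)c1`, gives 33 nM. Compound 3 `O=C1Nc2c(C(F)(F)F)cccc2[C@@]1(c1ccc(O)cc1)N1CCC(F)CC1` keeps the core of compound 1 but carries 4-fluoropiperidin-1-yl in place of 4,4-difluorocyclohexyl on a saturated ring carbon. Among the compounds with values here, no measured pair shows what such a swap does in this assay, so any forecast is loose. The incoming ring is again six-membered and non-aromatic, so only a small step with no clear gain in potency is expected, a step that the limit leaves unreadable from compound 1 to compound 3. For compound 3, the estimated half-maximal inhibitory concentration is 1500 nM, with an expected range of 300 nM to 6000 nM.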

Compound 3, half-maximal inhibitory concentration: > 1000 nM
Compound 3: only a limit was reported (the forecaster's own chance of this, stated with the estimate: 50%); the middle value does not contradict the limit.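

Compound 1 and compound 3 both stand at a limit of the assay and not at a number, so no step can be read between them: the limit of > 1000 nM in this assay, at which 2 of the 3 values shown sit. The compounds shown leave open whether 4-fluoropiperidin-1-yl in place of 4,4-difluorocyclohexyl changes potency at all, and in which direction.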